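Cytotoxicity of quinaldine ureas: an unmeasured ortho-aminophenyl analogue

The compounds below may be only part of what the source reports. "The series", "measured", "known", "first", "only" and "open" are said of these compounds alone.

Compound 1 `Cc1cc(NC(=O)Nc2ccc(N)cc2)c2ccccc2n1` in an ADME assay on BJ cells (Homo sapiens) for cytotoxicity, with a stated time of 72 h (on this read-out higher numbers stand for an effect only at larger amounts of compound and lower numbers for an effect already at smaller amounts), gives > 25000 nM, a limit of the assay rather than a number. Compound 2 `Cc1cc(NC(=O)Nc2cccc(Cl)c2)c2ccccc2n1` in this assay gives > 25000 nM, again only a limit. Compound 3 `Cc1cc(NC(=O)Nc2ccc(O)cc2)c2ccccc2n1` in this assay gives > 25000 nM, also a limit.

For the measured compounds named here, compound 3 therefore stands at the same limit as every other compound measured in this assay; all three values sit together at the limit of > 25000 nM in this assay, at which 3 of the 3 values shown sit, and no compound can be placed above or below another. The steps among them are accordingly unreadable: a step that the two limits leave unreadable from compound 1 to compound 2, a step that the two limits leave unreadable from compound 1 to compound 3, and a step that the two limits leave unreadable from compound 2 to compound 3.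

Compound 4 `Cc1cc(NC(=O)Nc2ccccc2N)c2ccccc2n1` has not yet been measured. It differs from compound 3 in one place: 2-aminophenyl in place of 4-hydroxyphenyl on an amide-type nitrogen. Going by the values given here, the steps that bear on this change, all between compounds whose values are limits, give no readable size, so no direction of change can be drawn from them. Among the compounds with values here, since compound 1, compound 2 and compound 3 all sit at the limit in this assay, compound 4 is expected to do the same, with the step from compound 3 expected to be no more than a step that the limit leaves unreadable from compound 3 to compound 4. Compound 4 is therefore estimated at 30000 nM, within a range of 15000 nM to 60000 nM, most probably reported again only as a limit.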

Compound 4, half-maximal effective concentration: > 25000 nM
Compound 4 ended at the assay's limit; the forecaster's own chance of this, stated with the estimate: 85%; the middle value does not contradict the limit.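

Compound 4, like compound 1, compound 2 and compound 3, gives only a limit and not a number, so none of its steps to those three compounds can be read in this assay: the limit of > 25000 nM in this assay, at which 4 of the 4 values shown sit. The compounds shown leave open how these four compare with one another and at what amount any of them would show an effect.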